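The source may hold more compounds than are shown below. What is called first, only, known or untested is meant among the compounds shown, and "the series" means these compounds.

Compound 1 `CC(C)(C)c1cc(NC(=O)Nc2ccc(-c3cn4ccc(Cl)cc4n3)cc2)no1` and compound 2 `Cc1ccn2cc(-c3ccc(NC(=O)Nc4cc(C(C)(C)C)on4)cc3)nc2c1` share one core and differ in a single place. In a functional assay on MV4-11 cells (Homo sapiens) for cytotoxicity, read by MTT assay, with a stated time of 72 h (on this read-out lower numbers stand for stronger inhibition and higher numbers for weaker inhibition), compound 1 gives 5.91 nM and compound 2 gives 0.79 nM; the change methyl in place of chloro on an aromatic carbon produces a 7.5-fold lower number from compound 1 to compound 2 (0.87 log units; beyond the scatter). Compound 3 `CC(C)(C)c1cc(NC(=O)Nc2ccc(-c3cn4c(Cl)cccc4n3)cc2)no1` has the same atoms as compound 1 joined differently, and the difference between the two cores is not broken down here. In this assay compound 3 gives 56.1 nM, the highest number among the three measured compounds. Compound 4 `Cc1cccc2nc(-c3ccc(NC(=O)Nc4cc(C(C)(C)C)on4)cc3)cn12` carries the same kind of change relative to compound 3 as compound 2 carries relative to compound 1, namely (methyl in place of chloro on an aromatic carbon), but the surroundings of the place differ: in compound 4 the methyl sits next to the ring nitrogen, ortho to a fused ring and meta to a fused ring, whereas in compound 2 it is meta to a fused ring, opposite the ring nitrogen and para to a fused ring. Resting on a 7.5-fold lower number from compound 1 to compound 2 (0.87 log units; beyond the scatter), compound 4 is expected to show a 5.6-fold lower number from compound 3 to compound 4 (0.75 log units; beyond the scatter), with the differing place making the size less certain. Compound 4 is therefore estimated at 10 nM, between 3 nM and 40 nM.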

Compound 4, half-maximal inhibitory concentration: 20.2 nM
The estimate for compound 4 lay 2.0-fold (0.31 log units) below the measured number; low and high end bracket the measured number.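

In this assay, methyl in place of chloro on the aromatic carbon next to the ring nitrogen gives a 2.8-fold lower number from compound 3 to compound 4 (0.44 log units; beyond the scatter), so the change lowers the number on this core as it does on the core of compound 1. The direction is thus shared by both pairs, but the size is not, and the two steps differ by more than repeated measurements would explain: the same change on two cores in this assay, a 7.5-fold lower number (0.87 log units; beyond the scatter) from compound 1 to compound 2 and a 2.8-fold lower number (0.44 log units; beyond the scatter) from compound 3 to compound 4, 2.7-fold (0.43 log units) apart, beyond the scatter of two such steps. Going by these compounds alone, this shows that a step measured at one place on the ring cannot simply be carried over at full size to another, but with only two pairs it gives no general rule, and it does not show what sets the size of the step.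

The compounds shown leave open how a methoxy group, an amine or a nitrile would compare with methyl and chloro at these places. They also leave open whether methyl in place of chloro would lower the number at the other aromatic carbons of the six-membered ring.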